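This account rests on a few compounds, and the source may have more. Where it says the series, first, only, none or still open, it means among the compounds named here.

In a functional assay on ASPC1 cells (Homo sapiens) for antiproliferative activity, read by MTT assay, with a stated time of 72 h (on this read-out lower numbers stand for stronger inhibition and higher numbers for weaker inhibition), compound 2 `C=CC(=O)Nc1cc(Nc2nccc(NC(=O)c3ccc(C(F)(F)F)cc3)n2)c(OC)cc1N1CCN(C)CC1` gives > 10000 nM, which is a limit of the assay and not a number. Compound 2 therefore stands at the limit of > 10000 nM in this assay, at which 1 of the 3 values shown sits. Compound 1 `C=CC(=O)Nc1cc(Nc2nccc(NC(=O)c3cccc4ccccc34)n2)c(OC)cc1N1CCN(C)CC1` gives 6600 nM.

Compound 4 `C=CC(=O)Nc1cc(Nc2nccc(NC(=O)c3ccc(C(F)(F)F)cc3)n2)c(OC)cc1N(C)CCN(C)C` has not yet been measured. It differs from compound 2 in one place (2-(dimethylamino)ethyl)(methyl)amino in place of 4-methylpiperazin-1-yl on an aromatic carbon: (2-(dimethylamino)ethyl)(methyl)amino replaces 4-methylpiperazin-1-yl on an aromatic carbon, and the entering group has no ring.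

Among the compounds with values here, the one measured step, an at least 1.5-fold higher number from compound 1 to compound 2 (0.18 log units; that floor lies within the scatter), concerns a change on a carbonyl carbon, so it gives no size for this replacement. Compound 3 `C=CC(=O)Nc1cc(Nc2nccc(NC(=O)c3ccccc3)n2)c(OC)cc1N(C)CCN(C)C`, which carries the same entering group, gives a true number, 3580 nM. On that basis, a modest move toward lower numbers is expected, though the result could remain at the limit. The expected change is an at least 1.6-fold lower number from compound 2 to compound 4 (0.22 log units; that floor lies within the scatter). The estimate for compound 4 is 6000 nM, with an expected range from 2500 nM to 12000 nM.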

Compound 4, half-maximal inhibitory concentration: 8030 nM
Compound 4: middle estimate off by 1.3-fold (0.13 log units), on the low side, within the range that was stated.
By their numbers in this assay, from the lowest: compounds 3, 1 and 4 (each within the scatter of the next, the first and the last beyond it). At a limit, above all of these: compound 2.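

In this assay, (2-(dimethylamino)ethyl)(methyl)amino in place of 4-methylpiperazin-1-yl on this aromatic carbon gives an at least 1.2-fold lower number from compound 2 to compound 4 (0.09 log units; that floor lies within the scatter). The value of compound 2 is a limit, so this step gives a floor and not a true size: the limit of > 10000 nM in this assay, at which 1 of the 4 values shown sits. Within the data shown here, with the ringless group held fixed, trifluoromethyl in place of hydrogen gives a 2.2-fold higher number from compound 3 to compound 4 (0.35 log units; beyond the scatter), the first step that lies beyond the scatter and a first sign that the group on the carbonyl side can shift the number.

From the compounds shown here alone, the real size of the amine replacement stays open until it can be read between two true numbers. Also open, going by these compounds, is how a morpholin-4-yl group or a longer amine chain at this aromatic carbon would compare, and how a chlorine would compare with trifluoromethyl.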